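This account rests on a few compounds, and the source may have more. Where it says the series, first, only, none or still open, it means among the compounds named here.

Working notes on a functional assay on HeLa cells (Homo sapiens) for inhibition, read by CCK-8 assay, with a stated time of 72 h, tested at 2 uM; a lower number here means less inhibition of growth, a higher number more inhibition of growth at the concentration tested. Going by the values given here, compound 1 (`COc1ccc(SCc2ccc(C(=O)Nc3ccccc3N)cc2)cc1`) gives 35%, the higher of the two numbers available so far. Compound 2 (`COc1ccc(SCc2ccc(C(=O)Nc3ccccc3N)cc2)cc1OC`) gives 15.2%. Among the compounds with values here, the only measured step is a number 19.8 percentage points lower from compound 1 to compound 2 (beyond the scatter), and the change there is methoxy in place of hydrogen on an aromatic carbon.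

The next compound is compound 3 (`Cc1cc(C)cc(SCc2ccc(C(=O)Nc3ccccc3N)cc2)c1`), which keeps the core of compound 1 and carries this change: 3,5-dimethylphenyl in place of 4-methoxyphenyl on a sulfur. The measured step bears on this only indirectly. Within the data shown here, it also concerns the aromatic group on the sulfur, but no measured compound has lost the methoxy or carries methyl groups. Among the measured compounds shown here, with one step as the sole guide, a modest fall is expected in this assay, probably smaller than a number 19.8 percentage points lower from compound 1 to compound 2 (beyond the scatter), and no change beyond the scatter remains possible.

The estimate corresponds to an expected a number 8 percentage points lower from compound 1 to compound 3 (within the scatter). For compound 3 the estimated value is 27%, with an expected range of 10% to 47%.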

Compound 3, percent growth inhibition at one concentration: 40.2%
Beside the measured number, compound 3's estimate is 13.2 percentage points below it; the measured number falls inside the stated range.
By their numbers in this assay, from the lowest: compound 2; then compounds 1 and 3 (each within the scatter of the next).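

In this assay, the whole aromatic group on the sulfur can be exchanged with no change beyond the scatter: a number 5.2 percentage points higher from compound 1 to compound 3 (within the scatter). Compound 1 therefore does not depend on its 4-methoxyphenyl group for this level of growth inhibition, since 3,5-dimethylphenyl, a group of carbon only with no hydrogen-bond acceptor, gives a number that cannot be told apart from it. Going by these compounds alone, the earlier step, a number 19.8 percentage points lower from compound 1 to compound 2 (beyond the scatter), showed only a loss on adding a methoxy, so this position is now seen to accept at least one change without a loss, and nothing measured so far gives a reason for the difference between the two outcomes.

The compounds shown leave open which feature of the 3,5-dimethylphenyl group matters, if any, as a plain phenyl or a phenyl with a single methyl would separate the two methyl groups from the ring itself. They also leave open how far this position tolerates other kinds of group, such as a carboxylic acid, an amine or a chlorine atom on the ring, and whether the sulfur itself can give way to an oxygen atom.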